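Notes on the step from compound 3 to compound 4

The compounds below may be only part of what the source reports. "The series", "measured", "known", "first", "only" and "open" are said of these compounds alone.

Values in an assay on isolated protein for inhibition of ubiquitin carboxyl-terminal hydrolase 7 (Homo sapiens), with stated times of 30 min and 2 h; on this read-out lower numbers stand for stronger inhibition and higher numbers for weaker inhibition:
compound 1 `Cn1nc2c(=O)n(CC3(O)CCN(Cc4ccc(-c5ccco5)cc4Cl)CC3)cnc2c1-c1ccc(CNS(C)(=O)=O)cc1`: 65.3 nM
compound 2 `Cn1nc2c(=O)n(CC3(O)CCN(Cc4ccc(-c5ccco5)cc4Cl)CC3)cnc2c1-c1ccc(F)cc1`: 64.5 nM
compound 3 `Cn1nc2c(=O)n(CC3(O)CCN(Cc4ccc(-c5ccco5)cc4Cl)CC3)cnc2c1-c1ccc(C(N)=O)cc1`: 80.8 nM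

Compound 3 gives the highest of the three numbers, but this standing carries no weight since a 1.2-fold higher number from compound 1 to compound 3 (0.09 log units; within the scatter) and a 1.3-fold higher number from compound 2 to compound 3 (0.10 log units; within the scatter) both lie within the scatter. The three measured compounds differ only at one aromatic carbon, and the remaining step there, a 1.0-fold lower number from compound 1 to compound 2 (0.01 log units; within the scatter), is likewise within the scatter.

Compound 4 `Cn1nc2c(=O)n(CC3(O)CCN(Cc4ccc(-c5ccco5)cc4Cl)CC3)cnc2c1-c1ccc(CNC=O)cc1` is the next member; the change is (formylamino)methyl in place of carbamoyl on an aromatic carbon. All three measured steps at this same place are within the scatter, so no step beyond the scatter in this assay is expected in either direction. Compound 4 is therefore expected to give 75 nM, within 38 nM to 150 nM, an estimated step of a 1.1-fold lower number from compound 3 to compound 4 (0.03 log units; within the scatter).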

Compound 4, half-maximal inhibitory concentration: 20.9 nM
For compound 4 the middle estimate is 3.6-fold (0.55 log units) above the measured one, and the stated range ends above it.
By their numbers in this assay, from the lowest: compound 4; then compounds 2, 1 and 3 (each within the scatter of the next).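

At this aromatic carbon, (formylamino)methyl gives the only steps beyond the scatter in this assay among the compounds shown: a 3.9-fold lower number from compound 3 to compound 4 (0.59 log units; beyond the scatter), and a 3.1-fold lower number from compound 2 to compound 4 (0.49 log units; beyond the scatter). The closest comparison is on the amine nitrogen, where formyl in place of methylsulfonyl gives a 3.1-fold lower number from compound 1 to compound 4 (0.49 log units; beyond the scatter); compound 1 keeps the same carbon link and amine nitrogen, so that link alone does not go with the lower number. No measurement shown bears on the reason for this step.

On these data alone, it remains open whether other acyl groups, such as acetyl, or a urea on that nitrogen behave like formyl. A longer chain between the ring and the nitrogen is also untested in these compounds.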